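The source may report more compounds than this note shows. Statements on the series, on what has been measured and on what is new or still open speak of the compounds shown alone.

Working notes on the series. Among the compounds with values here, in a functional assay on U-251 cells (Homo sapiens) for inhibition, read by sulforhodamine B assay, with a stated time of 72 h (on this read-out lower numbers stand for an effect already at smaller amounts and higher numbers for an effect only at larger amounts of compound), compound 1 (`CC(C)(C)c1ccc(C(=O)/C=C/c2ccc([N+](=O)[O-])o2)cc1`) gives 44500 nM and compound 2 (`O=C(/C=C/c1ccc([N+](=O)[O-])o1)c1ccc(C2CCCCC2)cc1`) gives 4400 nM as the lowest of the two numbers so far. Within the data shown here, the only measured step is a 10-fold lower number from compound 1 to compound 2 (1.00 log units; beyond the scatter) and it is modest but beyond the scatter, with cyclohexyl in place of tert-butyl on an aromatic carbon. Compound 3 (`O=C(/C=C/c1ccc([N+](=O)[O-])o1)c1ccc(N2CCCCC2)cc1`) differs from compound 2 by one change, piperidin-1-yl in place of cyclohexyl on an aromatic carbon para to a large group (piperidin-1-yl in place of cyclohexyl on an aromatic carbon). Among the measured compounds shown here, only that one measured step bears on this place. For the measured compounds named here, it shows that the number in this assay can move when the group there changes, yet both of its groups hold carbon only, and no measured compound has a nitrogen in the ring at this place. The working expectation in this assay is therefore no step beyond the scatter, with a slight lean toward a higher number and a wide margin. The estimated step is a 1.4-fold higher number from compound 2 to compound 3 (0.13 log units; within the scatter) on this expectation. For compound 3 the estimate is 6000 nM with an expected range from 1800 nM to 20000 nM in this series.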

Compound 3, half-maximal effective concentration: > 50000 nM
Compound 3 ended at the assay's limit; the forecaster's own chance of this, stated with the estimate: 5%; middle value at least 8.3-fold (0.92 log units) from the limit.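

In this assay compound 3 ends at a limit of the assay and not at a number: the limit of > 50000 nM in this assay, at which 1 of the 3 values shown sits.

Even so, the change from cyclohexyl to piperidin-1-yl, a six-membered non-aromatic ring for a six-membered non-aromatic ring with one nitrogen entering, gives an at least 11-fold higher number from compound 2 to compound 3 (1.05 log units; beyond the scatter), so the number at this place on an aromatic carbon para to a large group responds to a nitrogen in the ring and not only to a change between groups of carbon alone. The comparison with tert-butyl gives only an at least 1.1-fold higher number from compound 1 to compound 3 (0.05 log units; that floor lies within the scatter), so this floor does not set piperidin-1-yl apart from tert-butyl, and the advantage of compound 2 over compound 1 does not carry over to compound 3.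

As far as these compounds go, how far the true value of compound 3 lies past the limit stays open, and so does the size of any gap between compound 1 and compound 3. Also open, from the compounds shown here alone, is whether the loss follows this one ring or any nitrogen at this place, a question that morpholin-4-yl, piperazin-1-yl or an open-chain dimethylamino group would bear on.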